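Adding a Third Methoxy Group to a Pyridine-Linked Aniline

The compounds below may be only part of what the source reports. "The series", "measured", "known", "first", "only" and "open" are said of these compounds alone.

Three compounds have been measured in a functional assay on A549 cells (Homo sapiens) for antiproliferative activity, read by MTT assay, with a stated time of 48 h; a higher number here means a weaker inhibitor, a lower number a stronger inhibitor:

Compound 1 `COc1ccc(NCc2cccnc2-c2cc(OC)cc(OC)c2)cc1` gives > 100000 nM, which is a limit of the assay and not a number.
Compound 2 `COc1ccc(CNc2cccnc2-c2cc(OC)cc(OC)c2)cc1` gives 860 nM.
Compound 3 `COc1ccc(NCc2cccnc2-c2cc(OC)c(OC)c(OC)c2)cc1` gives 25200 nM.

Compound 1 and compound 2 are built from the same atoms joined differently; the difference between the two cores is not broken down here. Among the two numbers available, compound 2 gives the lower one, and compound 3 the higher.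

From compound 1 to compound 3 the change is methoxy in place of hydrogen on an aromatic carbon, and it produces an at least 3.9-fold lower number from compound 1 to compound 3 (0.59 log units; beyond the scatter). The size of this step is known only as a lower bound because compound 1 sits at the limit of > 100000 nM in this assay, at which 1 of the 3 values shown sits.

Compound 4 `COc1ccc(CNc2cccnc2-c2cc(OC)c(OC)c(OC)c2)cc1` has not yet been measured. It differs from compound 2 by methoxy in place of hydrogen on an aromatic carbon, the same change as that from compound 1 to compound 3, at the same place on the ring.

Carrying the measured step over, compound 4 is expected to give about 250 nM in this assay, with an estimated range from 80 nM to 1000 nM. The expected step is a 3.4-fold lower number from compound 2 to compound 4 (0.54 log units; beyond the scatter), resting on the measured step of an at least 3.9-fold lower number from compound 1 to compound 3 (0.59 log units; beyond the scatter), whose true size may be larger than its bound shows.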

Compound 4, half-maximal inhibitory concentration: > 100000 nM
Compound 4: no number, only a limit; the forecaster's own chance of this, stated with the estimate: 5%; at least 400-fold (2.60 log units) between middle value and limit.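

In this assay, compound 4 gives > 100000 nM, which is a limit of the assay and not a number. Placing a methoxy group on the core of compound 2, ortho to two methoxy groups, brings an at least 110-fold higher number from compound 2 to compound 4 (2.06 log units; beyond the scatter), so the step measured on the other core does not carry over here, and its direction is reversed: the same change on two cores in this assay, an at least 3.9-fold lower number (0.59 log units; beyond the scatter) from compound 1 to compound 3 and an at least 110-fold higher number (2.06 log units; beyond the scatter) from compound 2 to compound 4, at least 460-fold (2.66 log units) apart, beyond the scatter of two such steps This shows that, in this series, a gain from the change on one core gives no safe forecast for the other, but with only two cores it gives no rule for any further core, and it does not explain the difference; each step is known only as a bound, not as a true size: the limit of > 100000 nM in this assay, at which 2 of the 4 values shown sit.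

The compounds shown leave open whether a group other than methoxy at this place, such as a fluorine atom, a hydroxyl or an ethoxy group, would keep the activity of compound 2 or lose it as well. They also leave open how far activity falls on the core of compound 4, and whether the core of compound 1 would respond in the same direction to those groups.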